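Smaller cycloalkyl ring on the shared core: compound 2 to 3

The source may hold more compounds than are shown below. What is called first, only, known or untested is meant among the compounds shown, and "the series" means these compounds.

Among the compounds with values here, in this series, compound 2 `COc1ccc(C(=O)n2c(C3CCCCC3)nc3ccccc32)cc1` gives 85 nM in a functional assay on HL-60 cells (Homo sapiens) for cytotoxicity, read by MTT assay, with a stated time of 72 h (a higher number here means a weaker inhibitor, a lower number a stronger inhibitor), the higher of the two numbers measured so far; compound 1 `COc1ccc(C(=O)n2c(CC(C)C)nc3ccccc32)cc1` gives 34 nM. Within the data shown here, the single measured step, a 2.5-fold higher number from compound 1 to compound 2 (0.40 log units; beyond the scatter), concerns a different change, so nothing bears directly on the present one. Compound 3 `COc1ccc(C(=O)n2c(C3CCCC3)nc3ccccc32)cc1` differs from compound 2 by cyclopentyl in place of cyclohexyl on an aromatic carbon. Given that the only known step is modest, a modest move toward the number of compound 1 is expected, a 1.4-fold lower number from compound 2 to compound 3 (0.15 log units; within the scatter), possibly within the scatter. Compound 3 is estimated at 60 nM, with a range of 25 nM to 150 nM.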

Compound 3, half-maximal inhibitory concentration: 76 nM
Beside the measured number, compound 3's estimate is 1.3-fold (0.10 log units) below it; measured number inside the range.
By their numbers in this assay, from the lowest: compound 1; then compounds 3 and 2 (each within the scatter of the next).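

The step of a 1.1-fold lower number from compound 2 to compound 3 (0.05 log units; within the scatter) leaves cyclohexyl and cyclopentyl on this aromatic carbon unresolved in this assay so, between these two rings, the change in ring size has no readable effect. Against isobutyl, the step of a 2.2-fold higher number from compound 1 to compound 3 (0.35 log units; beyond the scatter) stands beyond the scatter and lies close to a 2.5-fold higher number from compound 1 to compound 2 (0.40 log units; beyond the scatter) so both cycloalkyl compounds sit apart from compound 1 in the same direction. No supporting data explain this result.

Going by these compounds, how a cyclopropyl ring, a longer chain or an amine on this carbon would read remains open. So does whether any other open chain would track isobutyl.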